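Naphthamide piperidine series: benzyl methyl position

The compounds below may be only part of what the source reports. "The series", "measured", "known", "first", "only" and "open" are said of these compounds alone.

Measured so far:
compound 1 `O=C(NC1CCN(Cc2cccc(Br)c2)CC1)c1ccc2ccccc2c1`, 36 nM
compound 2 `Cc1cccc(CN2CCC(NC(=O)c3ccc4ccccc4c3)CC2)c1`, 11 nM

In an assay on isolated protein for displacement of a labelled ligand from D(4) dopamine receptor (Homo sapiens) (a higher number here means a weaker inhibitor, a lower number a stronger inhibitor), compound 2 gives the lowest number of the two, with compound 1 at 36 nM as its nearest neighbour; the step of a 3.3-fold lower number from compound 1 to compound 2 (0.51 log units; beyond the scatter) is modest but beyond the scatter. Compound 3 `Cc1ccc(CN2CCC(NC(=O)c3ccc4ccccc4c3)CC2)cc1` differs from compound 2 by 4-methylphenyl in place of 3-methylphenyl on a saturated chain carbon bound to an amine nitrogen in a ring. Going by the values given here, no measured step bears directly on this positional change; the only measured step concerns the nature of the substituent, not its place. The expectation for compound 3 is therefore a step of a 1.4-fold higher number from compound 2 to compound 3 (0.13 log units; within the scatter), not beyond the scatter in either direction. Compound 3 is estimated at 15 nM, with a range of 5 nM to 45 nM.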

Compound 3, inhibition constant: 21 nM
Estimate against measurement, compound 3: 1.4-fold (0.15 log units) below; the range from low to high includes it.
By their numbers in this assay, from the lowest: compounds 2, 3 and 1 (each within the scatter of the next, the first and the last beyond it).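

In this assay the change from 3-methylbenzyl to 4-methylbenzyl is a 1.9-fold higher number from compound 2 to compound 3 (0.28 log units; within the scatter) so the two methyl placements on this saturated chain carbon's phenyl are not told apart. The step of a 1.7-fold lower number from compound 1 to compound 3 (0.23 log units; within the scatter) also stays within the scatter, so compound 3 is not separated from compound 1 even though compound 2 is. No supporting data bear on this result.

Still open, from the compounds shown here alone, is whether a methoxy or trifluoromethyl group in place of the methyl would separate the two placements. The unsubstituted phenyl, as a reference for all three compounds, is also absent from the compounds shown.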